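The compounds below may be only part of what the source reports. "The series", "measured", "known", "first", "only" and "open" are said of these compounds alone.

Compound 1 `O=S(=O)(Cc1nc(-c2ccncc2)c2sccc2n1)c1cccc(Cl)c1`: > 50000 nM
Compound 2 `COc1ccc(-c2nc(CC(O)c3cccc(Cl)c3)nc3ccsc23)cn1`: 31000 nM

In an ADME assay on cells (Homo sapiens) for cytotoxicity, read by resazurin assay, with a stated time of 5 days (a lower number here means that less compound is tolerated, a higher number that more compound is tolerated), compound 1 gives > 50000 nM, which is a limit of the assay and not a number. Compound 3 `O=S(=O)(Cc1nc(-c2ccc(F)nc2)c2sccc2n1)c1cccc(Cl)c1` keeps the core of compound 1 but carries 6-fluoropyridin-3-yl in place of pyridin-4-yl on an aromatic carbon. Within the data shown here, no measured pair shows such a swap, so the expectation in this assay is a small move towards less compound tolerated, or none beyond the scatter. Compound 2 gives 31000 nM, so a number in that region is conceivable. The expected step is an at least 1.2-fold lower number from compound 1 to compound 3 (0.09 log units; that floor lies within the scatter). The estimate for compound 3 is 40000 nM, with a range of 18000 nM to 70000 nM.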

Compound 3, half-maximal cytotoxic concentration: 40000 nM
Compound 3: middle estimate and measured number agree at the digits printed; the range from low to high includes it.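

In this assay, among these compounds, the change to 6-fluoropyridin-3-yl in place of pyridin-4-yl gives an at least 1.2-fold lower number from compound 1 to compound 3 (0.09 log units; that floor lies within the scatter) and is the first step read at this position of the shared core. That step is only a floor, because compound 1 stands at a limit of the assay: the limit of > 50000 nM in this assay, at which 1 of the 3 values shown sits.

From the compounds shown here alone, compound 3 changes the ring's attachment and adds fluorine together, so the effect of each alone stays open. Going by these compounds, how this position would respond to an amine or a carboxylic acid in place of the pyridine ring also stays open.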